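Enantiomer swap on the fluorocyclopropane amide series

The source may report more compounds than this note shows. Statements on the series, on what has been measured and on what is new or still open speak of the compounds shown alone.

Measured so far in an assay on SH-EP1 cells for agonist activity at Neuronal acetylcholine receptor; alpha4/beta2 (Homo sapiens), read by FLIPR and calcium flux; a lower number here means that less compound is needed, a higher number that more compound is needed for the effect:
- compound 1 `O=C([C@H]1C[C@H]1F)N1CC2CC(C1)N2`: 1500 nM
- compound 2 `O=C([C@@H]1C[C@@H]1F)N1CC2CC(C1)N2`: 370 nM
- compound 3 `O=C([C@H]1C[C@@H]1F)N1CC2CC(C1)N2`: 2800 nM

Compound 3 gives the highest number of the three; compound 1 lies nearest, within the scatter (a 1.9-fold higher number from compound 1 to compound 3 (0.27 log units; within the scatter)), while compound 2 lies furthest (a 7.6-fold higher number from compound 2 to compound 3 (0.88 log units; beyond the scatter)).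

Compound 4 `O=C([C@@H]1C[C@H]1F)N1CC2CC(C1)N2` has not yet been measured in this assay. Its change from compound 3 is the two compounds have the same atoms and bonds; at least one stereo element is drawn with a configuration in one of them and without one in the other: 2 of 4 stereo elements differ; a stereocentre at a saturated ring carbon is drawn R in compound 3 and S in compound 4; a stereocentre at a saturated ring carbon is drawn S in compound 3 and R in compound 4; both stereocentres of the fluorocyclopropane flip together, so compound 4 is the mirror image of compound 3.

Among the compounds with values here, the one measured step of the same kind is the pair compound 1 and compound 2, which also differ at both stereocentres at once: a 4.1-fold lower number from compound 1 to compound 2 (0.61 log units; beyond the scatter). The single-centre steps a 1.9-fold higher number from compound 1 to compound 3 (0.27 log units; within the scatter) and a 7.6-fold higher number from compound 2 to compound 3 (0.88 log units; beyond the scatter) describe a different change and only frame the spread of the series. A step of modest size is therefore plausible for compound 4 in this assay, but the direction is not fixed by the numbers shown, since nothing tells which mirror image of the pair compound 3 and compound 4 corresponds to compound 2.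

The expected outcome for compound 4 is 1500 nM (400 nM to 6000 nM), which means an expected step of a 1.9-fold lower number from compound 3 to compound 4 (0.27 log units; within the scatter).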

Compound 4, half-maximal effective concentration: 870 nM
Compound 4: middle estimate off by 1.7-fold (0.24 log units), on the high side; the range from low to high includes it.
By their numbers in this assay, from the lowest: compound 2; then compounds 4, 1 and 3 (each within the scatter of the next, the first and the last beyond it).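

In this assay the second mirror-image pair also separates beyond the scatter (a 3.2-fold lower number from compound 3 to compound 4 (0.51 log units; beyond the scatter)), so inverting both stereocentres of the fluorocyclopropane together gives a measurable step in both pairs, not only in compound 1 and compound 2. Changing a single stereocentre now gives different outcomes: one such step stays within the scatter (a 1.7-fold lower number from compound 1 to compound 4 (0.24 log units; within the scatter)), while another lies beyond it (a 2.4-fold higher number from compound 2 to compound 4 (0.37 log units; beyond the scatter)). Within the data shown here, compound 2 remains the only compound whose steps to all three others lie beyond the scatter, which ties the lowest number in the set to that one arrangement of the two stereocentres.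

The compounds shown do not tell whether this ordering of the four stereoisomers would persist if a chlorine atom or a methyl group took the place of the fluorine, or if the cyclopropane gave way to a cyclobutane. They also leave open whether the same ordering would hold for the maximal response, since only the half-maximal concentration is given here.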